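Dropping One Methoxy Group from Compound 1

The source may hold more compounds than are shown below. What is called first, only, known or untested is meant among the compounds shown, and "the series" means these compounds.

Of the compounds shown here, two that share one core have been tested in an assay on HL-60 cells for inhibition of glutathione S-transferase P (Homo sapiens), read by spectrophotometry, tested at 20 uM; a higher number here means more inhibition at the concentration tested (going by the name of the read-out), a lower number less inhibition. Compound 1, `COc1cc(/C=C2\CN(CC(=O)O)c3c(C)cccc3C2=O)cc(OC)c1OC`, carries three methoxy groups on one aromatic ring; in this assay compound 1 gives 0.85%. Compound 2, `COc1cccc(/C=C2\CN(CC(=O)O)c3c(C)cccc3C2=O)c1OC`, carries two methoxy groups there; in this assay compound 2 gives 8.1%. Numerically compound 1 sits at the bottom of these two readings, but its gap to compound 2 lies within the usual scatter, so the two cannot be told apart. Both stand near the floor of the scale, meaning little of the enzyme is blocked at the concentration tested.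

Compound 3, `COc1cc(/C=C2\CN(CC(=O)O)c3c(C)cccc3C2=O)cc(OC)c1`, is compound 1 with a single change: hydrogen in place of methoxy on an aromatic carbon. For the measured compounds named here, no measured pair shows what this kind of change does in this assay, so the step size is unknown. Because compound 1 gives 0.85% and compound 2 gives 8.1%, another weak reading seems likely. The expected step, a number 3.2 percentage points higher from compound 1 to compound 3 (within the scatter), should stay within the scatter. Compound 3 is estimated to give 4%, in a range from -5% to 15%.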

Compound 3, a percentage reported as inhibition, at one concentration (the size of the read-out at that concentration, not a potency): 32.3%
Beside the measured number, compound 3's estimate is 28.3 percentage points below it; the measured number lies above the stated range.
By their numbers in this assay, from the lowest: compounds 1 and 2 (each within the scatter of the next); then compound 3.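

Hydrogen in place of the methoxy group that sits ortho to two methoxy groups and para to a large group gives a number 31.5 percentage points higher from compound 1 to compound 3 (beyond the scatter) in this assay, the first step that can be read in this series. This shows that a single group at this place on the aromatic ring matters: in this pair, the compound with methoxy there stays near the floor of the scale, while the compound with only hydrogen there does not. What lies behind the rise remains unexplained, as no measurement shown here speaks to its cause.

Open, from the compounds shown here alone, is whether the reading depends on removing the methoxy group as such or on what replaces it, which a hydroxyl group, a fluorine atom or an amine at the same place could test. Also open, going by these compounds, is whether the same change gives a step of similar size elsewhere on the shared core, since this is one pair read at one concentration and says nothing yet about potency.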